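Isopropyl in place of methyl on compound 2

The source may hold more compounds than are shown below. What is called first, only, known or untested is meant among the compounds shown, and "the series" means these compounds.

In an ADME assay (liver) for metabolic stability, with Liver microsome (Homo sapiens) as the target, using microsomes and NADPH, with a stated time of 30 min, tested at 1 uM (a lower number here means slower removal, a higher number faster removal of the compound), compound 1 `Nc1ccc(S(=O)(=O)N2CCN(c3ncc(C(O)(C(F)(F)F)C(F)(F)F)cc3C3CC3)CC2)cn1` gives 38 mL.min-1.g-1 and compound 2 `Cn1cc(-c2cc(C(O)(C(F)(F)F)C(F)(F)F)cnc2N2CCN(S(=O)(=O)c3ccc(N)nc3)CC2)cn1` gives 19 mL.min-1.g-1. The two compounds differ by 1-methyl-1H-pyrazol-4-yl in place of cyclopropyl on an aromatic carbon, recorded as a 2.0-fold lower number from compound 1 to compound 2 (0.30 log units; within the scatter), so compound 2 stands level with compound 1 on these two numbers. Compound 3 `CC(C)n1cc(-c2cc(C(O)(C(F)(F)F)C(F)(F)F)cnc2N2CCN(S(=O)(=O)c3ccc(N)nc3)CC2)cn1` keeps the rest of compound 2 and carries isopropyl in place of methyl on an aromatic nitrogen. Going by the values given here, that single measured step bears on the change only indirectly, since no measured pair varies the group on this nitrogen. With so little evidence, only a small rise in this assay is expected, no larger than the scatter. The expected change is a 1.4-fold higher number from compound 2 to compound 3 (0.14 log units; within the scatter). For compound 3 the estimated value is 26 mL.min-1.g-1, with an expected range of 13 mL.min-1.g-1 to 48 mL.min-1.g-1.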

Compound 3, intrinsic clearance in microsomes: 38 mL.min-1.g-1
Estimate against measurement, compound 3: 1.5-fold (0.16 log units) below, and the stated range covers the measured number.
By their numbers in this assay, from the lowest: compounds 2, 1 and 3 (each within the scatter of the next).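

Going by these compounds alone, this is the first measured pair that varies the group on the aromatic nitrogen: in this assay, isopropyl in place of methyl gives a 2.0-fold higher number from compound 2 to compound 3 (0.30 log units; within the scatter). Two further carbons at this position therefore leave the intrinsic clearance in microsomes within the scatter, so the pair shows no measurable effect of this change. Exchanging cyclopropyl for 1-isopropyl-1H-pyrazol-4-yl on the aromatic carbon gives no change at the digits printed from compound 1 to compound 3 (within the scatter), and so this swap, too, shows no effect beyond the scatter. Nothing available here bears on the reason for these numbers.

The compounds shown leave open whether a hydrogen, a longer chain or a chain ending in an amine or a carboxylic acid on this nitrogen would move the number beyond the scatter. They also leave open whether the same replacement would read alike on a different core.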